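The source may hold more compounds than are shown below. What is called first, only, known or untested is meant among the compounds shown, and "the series" means these compounds.

In a functional assay on MCF7 cells (Homo sapiens) for cytotoxicity, read by MTT assay, with a stated time of 48 h (on this read-out higher numbers stand for weaker inhibition of growth and lower numbers for stronger inhibition of growth), three compounds that share a core have been measured. Compound 1 `CCn1c(C(F)(F)F)nc2cc(Cl)c(Cl)cc21` gives 72900 nM, compound 2 `Clc1cc2ncn(C3CCCC3)c2cc1Cl` gives 42000 nM, and compound 3 `FC(F)(F)c1nc2cc(Cl)c(Cl)cc2n1C1CCCC1` gives 21000 nM. Compound 3 therefore stands clearly under compound 1 but cannot be told apart from compound 2.

The next compound, compound 4 `CS(=O)(=O)c1nc2cc(Cl)c(Cl)cc2n1C1CCCC1`, keeps the cyclopentyl group and alters one substituent, with methylsulfonyl in place of trifluoromethyl on an aromatic carbon.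

For the measured compounds named here, no measured compound carries methylsulfonyl, so the data offer no direct guide to this swap. The switch from ethyl to cyclopentyl on an aromatic nitrogen, a 3.5-fold lower number from compound 1 to compound 3 (0.54 log units; beyond the scatter), was modest, but it concerns another part of the molecule and says little here. The more relevant step is trifluoromethyl in place of hydrogen on the same aromatic carbon, a 2.0-fold lower number from compound 2 to compound 3 (0.30 log units; within the scatter). On these data alone, since that change stayed within the scatter, a step beyond the scatter in this assay is not expected, and the direction remains open. The estimated step is a 1.3-fold higher number from compound 3 to compound 4 (0.12 log units; within the scatter). The estimate for compound 4 is 28000 nM, with an expected range from 10000 nM to 70000 nM.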

Compound 4, concentration for 50% growth inhibition: 600 nM
Beside the measured number, compound 4's estimate is 47-fold (1.67 log units) above it, and the stated range ends above it.
By their numbers in this assay, from the lowest: compound 4; then compounds 3, 2 and 1 (each within the scatter of the next, the first and the last beyond it).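

For the compounds shown here, until now, the aromatic carbon between two ring nitrogen atoms seemed to matter little in this assay, since the one change seen there gave a 2.0-fold lower number from compound 2 to compound 3 (0.30 log units; within the scatter). Compound 4 shows that the group on this carbon can matter greatly: exchanging trifluoromethyl for methylsulfonyl, both counted at 4 heavy atoms, gives a 35-fold lower number from compound 3 to compound 4 (1.54 log units; beyond the scatter), although the two groups also differ in their atoms and in hydrogen-bond acceptors, 0 for trifluoromethyl and 2 for methylsulfonyl. The comparison with hydrogen on the same carbon gives a 70-fold lower number from compound 2 to compound 4 (1.85 log units; beyond the scatter), so methylsulfonyl stands apart from both the other substituents seen here, while no measurement shown explains why.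

The compounds shown leave open whether this large step is particular to methylsulfonyl or would also appear with a nitrile, an amide or a longer ethylsulfonyl group on the same carbon. They also leave open whether methylsulfonyl would give a similar step with ethyl in place of cyclopentyl on the aromatic nitrogen, as in compound 1.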